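From 4-Fluorophenyl to 3-Methoxyphenyl on a Sulfonyl Sulfur

The source may report more compounds than this note shows. Statements on the series, on what has been measured and on what is new or still open speak of the compounds shown alone.

Of the compounds shown here, three have been measured in a functional assay on HeLa cells for antagonist activity at 5-hydroxytryptamine receptor 6 (Homo sapiens); on this read-out lower numbers stand for smaller maximal responses and higher numbers for larger maximal responses. Compound 1 `CCCn1nc(S(=O)(=O)c2cccc3ccccc23)c2cc(N3CCNCC3)ccc21` gives 99%, compound 2 `CN1CCN(c2ccc3[nH]nc(S(=O)(=O)c4ccc(F)cc4)c3c2)CC1` gives 98%, and compound 3 `CC(C)Cn1nc(S(=O)(=O)c2cccc3ccccc23)c2cc(N3CCN(C)CC3)ccc21` gives 100%. Compound 2 has the lowest of the three numbers, yet its gaps to compound 1 and to compound 3 both lie within the usual scatter, so no order among them can be read. Compound 4 `COc1cccc(S(=O)(=O)c2n[nH]c3ccc(N4CCN(C)CC4)cc23)c1` has not yet been measured in this assay. It differs from compound 2 in one place: 3-methoxyphenyl in place of 4-fluorophenyl on a sulfonyl sulfur. Among the compounds with values here, no step between measured compounds exists to gauge such a change. Because compound 2 gives 98%, compound 4 is expected to show a step of a number 1 percentage points lower from compound 2 to compound 4 (within the scatter) of no size beyond the scatter. Compound 4 is estimated at 97%, between 85% and 105%.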

Compound 4, largest response reached (reported as Imax), in percent of the reference or control that the assay uses: 100%
For compound 4 the middle estimate is 3 percentage points below the measured one; the range from low to high includes it.
By their numbers in this assay, from the lowest: compounds 2, 1, 3 and 4 (each within the scatter of the next).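

In this assay, within the data shown here, the change from 4-fluorophenyl to 3-methoxyphenyl on a sulfonyl sulfur gives the first step that can be read at this position: a number 2 percentage points higher from compound 2 to compound 4 (within the scatter). The sulfonyl sulfur thus takes 3-methoxyphenyl, with its hydrogen-bond acceptor, with no step beyond the scatter. No measurement shown bears on what lies behind this result. Going by these compounds, it remains open whether a carboxylic acid or an amine on the aromatic ring at this sulfonyl sulfur would also stay within the scatter.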